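Bromo substitution on two pyridyl cores at alpha3/beta4

This account rests on a few compounds, and the source may have more. Where it says the series, first, only, none or still open, it means among the compounds named here.

Compound 1 `c1cncc(N2CC[C@@H]3CN[C@@H]3C2)c1`: 260 nM
Compound 2 `Brc1cncc(N2CC[C@@H]3CN[C@@H]3C2)c1`: 950 nM
Compound 3 `COc1cncc(N2CC[C@H]3CN[C@H]3C2)c1`: 180 nM

Three compounds were measured in a functional assay on HEK293 cells for agonist activity at Neuronal acetylcholine receptor; alpha3/beta4 (Homo sapiens), read by FLIPR; on this read-out lower numbers stand for an effect already at smaller amounts and higher numbers for an effect only at larger amounts of compound. Compound 1 differs from compound 2 by bromo in place of hydrogen on an aromatic carbon, and this step gave a 3.7-fold higher number from compound 1 to compound 2 (0.56 log units; beyond the scatter). Compound 3 sits within the scatter of compound 1, while the difference between the cores of compound 3 and compound 1 is not broken down here.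

Compound 4 `COc1cc(N2CC[C@H]3CN[C@H]3C2)cnc1Br` is not yet measured. It differs from compound 3 by bromo in place of hydrogen on an aromatic carbon. This is the same kind of change as that from compound 1 to compound 2, though the place is not the same: here the bromo enters next to the ring nitrogen, ortho to a methoxy group and para to a group of 8 heavy atoms, whereas before it sat two atoms from the ring nitrogen and meta to that group. Resting on the step of a 3.7-fold higher number from compound 1 to compound 2 (0.56 log units; beyond the scatter), a step of a 3.3-fold higher number from compound 3 to compound 4 (0.52 log units; beyond the scatter) is expected for compound 4. Compound 4 is therefore estimated at 600 nM, between 250 nM and 1500 nM.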

Compound 4, half-maximal effective concentration: 8 nM
The estimate for compound 4 lay 75-fold (1.88 log units) above the measured number; measured number below the stated range.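

In this assay, bromo in place of hydrogen on an aromatic carbon gave a 23-fold lower number from compound 3 to compound 4 (1.35 log units; beyond the scatter) and so did not carry over from the core of compound 1 in size or direction, as the two steps show: the same change on two cores in this assay, a 3.7-fold higher number (0.56 log units; beyond the scatter) from compound 1 to compound 2 and a 23-fold lower number (1.35 log units; beyond the scatter) from compound 3 to compound 4, 82-fold (1.91 log units) apart, beyond the scatter of two such steps.
The earlier step therefore cannot be applied as it stands to this core. The pair of steps does not show what separates them: the cores differ, only the second pair carries a methoxy group, and the bromo stands in a different place, here next to the ring nitrogen and ortho to a methoxy group.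

The compounds shown leave open whether the large step belongs to bromo itself or to its place beside the methoxy group's ring position. They also leave open whether a chloro or methyl group in that place would follow compound 4.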